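Dropping the chloro from compound 2: what follows?

This account rests on a few compounds, and the source may have more. Where it says the series, first, only, none or still open, it means among the compounds named here.

Compound 1 `O=C(Nc1nn[nH]n1)c1cc(Br)ccn1`: 34%
Compound 2 `O=C(Nc1nn[nH]n1)c1cc(Cl)ccn1`: 72%

In a functional assay on the whole organism for inhibition, with Rattus norvegicus as the target, at a dose of 3 mg/kg by the oral route (a higher number here means a stronger effect of the compound at the dose given, a lower number a weaker effect), compound 2 stands highest of the two measured compounds, with compound 1 nearest and clearly lower. Compound 3 `O=C(Nc1nn[nH]n1)c1ccccn1` differs from compound 2 in one place: hydrogen in place of chloro on an aromatic carbon. For the measured compounds named here, the only measured step that bears on this is the halogen swap a number 38 percentage points higher from compound 1 to compound 2 (beyond the scatter), which was large, so a change at this carbon can move the read-out considerably. Going by the values given here, removing the halogen altogether has no direct precedent here, so the direction is uncertain. Compound 3 is therefore expected to lie around 55%, between 25% and 85%, an estimated step of a number 17 percentage points lower from compound 2 to compound 3 (beyond the scatter).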

Compound 3, a percentage reported as inhibition, in the whole organism at one dose (the size of the read-out at that dose, not a potency): 29%
The estimate for compound 3 lay 26 percentage points above the measured number; measured number inside the range.
By their numbers in this assay, from the lowest: compounds 3 and 1 (each within the scatter of the next); then compound 2.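

Hydrogen in place of chloro on this aromatic carbon gave a number 43 percentage points lower from compound 2 to compound 3 (beyond the scatter) and so the chloro of compound 2 carries the read-out at this dose. Hydrogen in place of bromo gave a number 5 percentage points lower from compound 1 to compound 3 (within the scatter) and so, among these three compounds, having a halogen at this carbon is not enough: chloro stands apart, while bromo and hydrogen cannot be told apart. Nothing available gives a reason for this. Still open, as far as these compounds go, is whether fluoro, methyl or methoxy at this carbon would match chloro, and whether chloro elsewhere on the ring would do the same.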